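Carbonate Promoiety Trimmed: Rat Plasma Stability Outlook

This account rests on a few compounds, and the source may have more. Where it says the series, first, only, none or still open, it means among the compounds named here.

Within the data shown here, compound 1, `C[C@@H](O)[C@H]1C(=O)N2C(C(=O)OCOC(=O)OC(C)(C)C)=C(S[C@@H]3CN[C@H](C(=O)Nc4cccc(C(=O)O)c4)C3)[C@H](C)[C@H]12`, stands at 0% in an ADME assay on a cell-free system (plasma, Rattus norvegicus) for metabolic stability, read by LC-MS, with a stated time of 60 min, at 37 degrees C, tested at 50 uM (a higher number here means that more of the compound is left, a lower number that less of the compound is left), the only other number coming from compound 2, `C[C@@H](O)[C@H]1C(=O)N2C(C(=O)OCOC(=O)OC(C)(C)C)=C(S[C@@H]3CN[C@H](C(=O)Nc4cccc(C(=O)OCOC(=O)OC(C)(C)C)c4)C3)[C@H](C)[C@H]12`, which gives 8% in this assay; the difference is a number 8 percentage points higher from compound 1 to compound 2 (within the scatter). Compound 3, `CC(C)OC(=O)OCOC(=O)C1=C(S[C@@H]2CN[C@H](C(=O)Nc3cccc(C(=O)O)c3)C2)[C@H](C)[C@@H]2[C@@H]([C@@H](C)O)C(=O)N12`, differs from compound 1 by hydrogen in place of methyl on a saturated chain carbon bound to an oxygen next to a carbonyl group and two saturated chain carbons. Among the measured compounds shown here, no measured step touches this group, and the single known step lies within the scatter, so no change beyond the scatter is expected in this assay. For compound 3 the estimate is 2%, with a range from 0% to 12%. Compound 3 is thus expected to show a number 2 percentage points higher from compound 1 to compound 3 (within the scatter).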

Compound 3, percent of the compound remaining in the plasma assay: 0%
Compound 3: middle estimate off by 2 percentage points, on the high side, within the range that was stated.
By their numbers in the plasma assay, from the lowest: compounds 1, 3 and 2 (each within the scatter of the next).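

Among these compounds, in the plasma assay the change from tert-butoxycarbonyl to isopropoxycarbonyl gives no change at the digits printed from compound 1 to compound 3 (within the scatter) and thus shows no readable effect at this position, which no earlier step had touched. In a physicochemical assay for metabolic stability, read by LC-MS, in phosphate buffer, with a stated time of 3 h, at pH 7.4, tested at 50 uM (on this read-out lower numbers stand for a less stable compound and higher numbers for a more stable compound), compound 1 gives > 95% as a limit of the assay. In the physicochemical assay compound 3 gives > 95% as a limit too, and the step between these two limits cannot be read: the limit of > 95% in the physicochemical assay, at which 2 of the 2 values shown sit.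

As far as these compounds go, whether a cyclohexyl group or a longer chain here would leave more compound in the plasma assay stays open. Also open, from the compounds shown here alone, is whether isopropoxycarbonyl would behave alike with the carboxylic acid replaced as in compound 2.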